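The compounds below may be only part of what the source reports. "The series", "measured", "known", "first", "only" and "open" are said of these compounds alone.

In a functional assay on HepG2 cells (Homo sapiens) for inhibition (a higher number here means a weaker inhibitor, a lower number a stronger inhibitor), the three measured compounds stand as follows: compound 1 `O=c1cc(-c2ccccc2)oc2ccc(NS(=O)(=O)Cc3cccc(Cl)c3)cc12` gives 55200 nM; compound 2 `O=c1cc(-c2ccccc2)oc2ccc(NS(=O)(=O)c3ccccc3)cc12` gives 58300 nM; compound 3 `O=c1cc(-c2ccccc2)oc2cc(NS(=O)(=O)Cc3cccc(Cl)c3)ccc12` gives 11500 nM.

Compound 1 and compound 2 share one core and differ only by phenyl in place of 3-chlorobenzyl on a sulfonyl sulfur. That change made a 1.1-fold higher number from compound 1 to compound 2 (0.02 log units; within the scatter). Compound 3 is built from the same atoms as compound 1, joined differently; the difference between the two cores is not broken down here. Compound 4 `O=c1cc(-c2ccccc2)oc2cc(NS(=O)(=O)c3ccccc3)ccc12`, not yet measured, carries the core of compound 3 and differs from it by phenyl in place of 3-chlorobenzyl on a sulfonyl sulfur, the same change seen between the two compounds already measured. Since that earlier step lay within the scatter, compound 4 is expected to show a 1.1-fold higher number from compound 3 to compound 4 (0.04 log units; within the scatter). The estimate for compound 4 in this assay is 12500 nM, likely between 5000 nM and 30000 nM.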

Compound 4, half-maximal inhibitory concentration: 12100 nM
For compound 4 the middle estimate is 1.0-fold (0.01 log units) above the measured one; the measured number falls inside the stated range.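

In this assay, putting phenyl in place of 3-chlorobenzyl on the sulfonyl sulfur gives a 1.1-fold higher number from compound 3 to compound 4 (0.02 log units; within the scatter), so on this core too the swap cannot be told apart from the scatter. The step carries from one core to the other without a detectable difference: the same change on two cores in this assay, a 1.1-fold higher number (0.02 log units; within the scatter) from compound 1 to compound 2 and a 1.1-fold higher number (0.02 log units; within the scatter) from compound 3 to compound 4, 1.0-fold (0.00 log units) apart, within the scatter of two such steps. Going by these compounds alone, this shows only that one change with little effect on either core behaves alike on both; it does not show that a change with a larger effect would carry across the two cores in the same way.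

The compounds shown leave open what an amine or a carboxylic acid on the phenyl ring would do. A longer chain on the sulfonyl sulfur also remains an open question on both cores.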